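This account rests on a few compounds, and the source may have more. Where it says the series, first, only, none or still open, it means among the compounds named here.

Compound 1 `COc1nc(C)c(Nc2nc(Cl)cn([C@H](CO)C3CC3)c2=O)cc1C`: in an assay on frontal cortex for displacement of a labelled ligand from corticotropin-releasing factor receptor 1 (Rattus norvegicus), with a stated time of 2 h (on this read-out lower numbers stand for stronger inhibition and higher numbers for weaker inhibition), compound 1 gives 88 nM.
Compound 2 `COc1nc(C)c(Nc2nc(Cl)cn([C@H](COC(=O)Nc3cccnc3)C3CC3)c2=O)cc1C`: in this assay compound 2 gives 10 nM.

Within the data shown here, compound 2 holds the lower of the two numbers measured so far, and its only neighbour is compound 1. Among the measured compounds shown here, the one step known, an 8.8-fold lower number from compound 1 to compound 2 (0.94 log units; beyond the scatter), came from attaching the whole carbamate group to the alcohol oxygen of compound 1. Compound 3 `CCNC(=O)OC[C@H](C1CC1)n1cc(Cl)nc(Nc2cc(C)c(OC)nc2C)c1=O` keeps that carbamate but changes its end: ethyl in place of pyridin-3-yl on an amide-type nitrogen. For the measured compounds named here, no measured pair shows what the ring on the carbamate nitrogen itself contributes, so the gain seen in an 8.8-fold lower number from compound 1 to compound 2 (0.94 log units; beyond the scatter) cannot be split between the carbamate and its aromatic ring. A smaller group there might give back part of that gain, so compound 3 is expected to land somewhat higher than compound 2 in this assay, with a 3.0-fold higher number from compound 2 to compound 3 (0.48 log units; beyond the scatter), at about 30 nM, estimated between 10 nM and 90 nM.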

Compound 3, half-maximal inhibitory concentration: 14 nM
Beside the measured number, compound 3's estimate is 2.1-fold (0.33 log units) above it; low and high end bracket the measured number.
By their numbers in this assay, from the lowest: compounds 2 and 3 (each within the scatter of the next); then compound 1.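

In this assay, the step of a 1.4-fold higher number from compound 2 to compound 3 (0.15 log units; within the scatter) shows that the aromatic ring on the carbamate nitrogen is not required to keep the number in this range: ethyl serves as well as pyridin-3-yl here. The step of a 6.3-fold lower number from compound 1 to compound 3 (0.80 log units; beyond the scatter) shows that a carbamate with no ring at all still stands clear of the free alcohol, so the gain seen earlier does not depend on the pyridin-3-yl group. No measurement available here explains this result.

The compounds shown leave open how much the group on this nitrogen can change, for example to a longer chain such as butyl or to a chain ending in an amine. They also leave open whether the carbamate nitrogen itself matters, a question that an acetyl ester on the same oxygen would address.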